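The source may report more compounds than this note shows. Statements on the series, on what has been measured and on what is new or still open speak of the compounds shown alone.

Of the compounds shown here, two have been measured in an assay on microsomes from liver for inhibition of 3-hydroxy-3-methylglutaryl-coenzyme A reductase (Rattus norvegicus); a higher number here means a weaker inhibitor, a lower number a stronger inhibitor. Compound 1 `Cc1cc(C)cc(-c2nc(C(F)(F)F)n(CC[C@@H](O)C[C@@H](O)CC(=O)O)c2-c2ccc(F)cc2)c1` gives 24 nM in this assay. Compound 2 `O=C(O)C[C@H](O)C[C@H](O)CCn1c(C(F)(F)F)nc(-c2ccc(F)cc2)c1-c1ccccc1` gives 201 nM, the higher of the two numbers and therefore the weaker inhibitor, a gap that lies beyond the usual scatter. Compound 3 `Cc1cc(C)cc(-c2c(-c3ccc(F)cc3)nc(C(F)(F)F)n2CC[C@@H](O)C[C@@H](O)CC(=O)O)c1` has not been measured; it differs from compound 2 by 3,5-dimethylphenyl in place of phenyl on an aromatic carbon. Within the data shown here, no measured pair shows exactly this change, so the size of its effect is open. Compound 3 is expected to give a lower number than compound 2, a step of a 3.4-fold lower number from compound 2 to compound 3 (0.53 log units; beyond the scatter), with an estimate of 60 nM and a likely range from 20 nM to 200 nM.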

Compound 3, half-maximal inhibitory concentration: 38 nM
The estimate for compound 3 lay 1.6-fold (0.20 log units) above the measured number; low and high end bracket the measured number.
By their numbers in this assay, from the lowest: compounds 1 and 3 (each within the scatter of the next); then compound 2.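

In this assay, 3,5-dimethylphenyl in place of phenyl on the ring carbon next to the ring nitrogen gives a 5.3-fold lower number from compound 2 to compound 3 (0.72 log units; beyond the scatter). Among these compounds, this is the first measured pair with a single change at this position, and it shows that the number responds to what is added to this phenyl ring. Nothing available explains the size of this step. As far as these compounds go, it remains open whether a chlorophenyl or a methoxyphenyl at this carbon would give a similar step. The compounds also do not show whether a single methyl group would be enough.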